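Removing the sugar from a labdane glycoside: compound 4

The source may report more compounds than this note shows. Statements on the series, on what has been measured and on what is new or still open speak of the compounds shown alone.

Three glycosides share a diterpene core and differ only in their sugar. Compound 1 `C=C[C@@](C)(CC[C@H]1C(C)=CC[C@H]2C(C)(C)CCC[C@]12C)O[C@@H]1O[C@@H](C)[C@@H](OC(C)=O)[C@H](O)[C@H]1O` carries an acetyl on the sugar; compound 2 `C=C[C@@](C)(CC[C@H]1C(C)=CC[C@H]2C(C)(C)CCC[C@]12C)O[C@@H]1O[C@H](C)[C@H](O)[C@H](O)[C@H]1O` and compound 3 `C=C[C@@](C)(CC[C@H]1C(C)=CC[C@H]2C(C)(C)CCC[C@]12C)O[C@@H]1O[C@@H](C)[C@@H](O)[C@H](O)[C@H]1O` are free of it. In a functional assay on A549 cells (Homo sapiens) for cytotoxicity, read by sulforhodamine B assay (on this read-out lower numbers stand for an effect already at smaller amounts and higher numbers for an effect only at larger amounts of compound), compound 1 gives 3.2 ug/mL, compound 2 gives 3.5 ug/mL and compound 3 gives 3.9 ug/mL. The three numbers sit together: the step of a 1.2-fold higher number from compound 1 to compound 3 (0.09 log units; within the scatter) and the step of a 1.1-fold higher number from compound 2 to compound 3 (0.05 log units; within the scatter) both fall within the scatter, and the fact that compounds 2 and 3 differ only in the configuration as drawn shows that the latter pair is a change of drawn configuration only.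

Compound 4 `C=C[C@](C)(O)CC[C@H]1C(C)=CC[C@H]2C(C)(C)CCC[C@]12C` is a larger departure: a hydrogen atom in place of a group of 10 heavy atoms (6 carbon, 4 oxygen; one six-membered non-aromatic ring with 1 hetero atom), on an oxygen on a saturated carbon. The sugar is gone and only the bare alcohol on the core remains. Going by these compounds, neither measured step covers such a change; both concern the sugar itself and neither moved the number beyond the scatter, so the sugar's decoration appears to matter little, while its complete loss is untested here. Among the measured compounds shown here, with no direct precedent, the step of a 1.5-fold higher number from compound 3 to compound 4 (0.19 log units; within the scatter) is estimated to be modest and uncertain, leaning toward a somewhat higher number. Compound 4 is therefore expected to give about 6 ug/mL in this assay, with a plausible range from 2 ug/mL to 20 ug/mL.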

Compound 4, concentration for half-maximal effect: 2.4 ug/mL
The estimate for compound 4 lay 2.5-fold (0.40 log units) above the measured number, and the stated range covers the measured number.
By their numbers in this assay, from the lowest: compounds 4, 1, 2 and 3 (each within the scatter of the next).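

At the oxygen on a saturated carbon, the whole sugar can give way to a hydrogen atom without the number in this assay leaving the scatter: the change reads as a 1.6-fold lower number from compound 3 to compound 4 (0.21 log units; within the scatter) and, starting from the other sugar form, as a 1.5-fold lower number from compound 2 to compound 4 (0.16 log units; within the scatter). The earlier compounds had shown this only for the acetyl on the sugar and for the drawn configuration; compound 4 extends it to the loss of the entire group of 10 heavy atoms, so among these compounds a number of this size does not depend on the sugar, and the bare alcohol on the core is enough to give it. The two readings agree, but they are not two unrelated tests, since their starting points are closely matched: the fact that compounds 2 and 3 differ only in the configuration as drawn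

What the compounds shown leave open is whether this position tolerates every group, for instance a sugar bearing an amine or a carboxylic acid, or a longer chain on the same oxygen. They also leave open how much of the number comes from the shared core itself, as every compound here carries that core unchanged.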